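A few compounds are considered here, and "the series" means these few. Any claim that something is new, unique, unknown or untested is made for them only; others in the source may bear on it.

Measured in a functional assay on the whole organism for inhibition, with Scenedesmus acutus as the target; a lower number here means a stronger inhibitor, a higher number a weaker inhibitor:
Compound 1 `CCCCOC(=O)c1cc(N2C(=O)C3=C(CCCC3)C2=O)c(F)cc1Cl`: 126 nM
Compound 2 `CC(C)COC(=O)c1cc(N2C(=O)C3=C(CCCC3)C2=O)c(F)cc1Cl`: 100 nM

Compound 2 has a single measured neighbour, compound 1, and the two values lie within the scatter of each other, so they cannot be ranked. Compound 3 `CCC(C)OC(=O)c1cc(N2C(=O)C3=C(CCCC3)C2=O)c(F)cc1Cl` keeps the shared core and alters only the chain: sec-butyl in place of isobutyl on an oxygen next to a carbonyl group. This places sec-butyl in place of isobutyl on an oxygen next to a carbonyl group. Within the data shown here, only one measured step bears on this change, since it also alters the chain on that oxygen: a 1.3-fold lower number from compound 1 to compound 2 (0.10 log units; within the scatter). Among the measured compounds shown here, that step stays within the scatter, but no measured compound carries sec-butyl, so the evidence is thin. No shift beyond the scatter is therefore expected in this assay. The expected step is a 1.1-fold higher number from compound 2 to compound 3 (0.04 log units; within the scatter). For compound 3 the estimated value is 110 nM, with an expected range from 45 nM to 280 nM.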

Compound 3, half-maximal inhibitory concentration: 60.3 nM
Beside the measured number, compound 3's estimate is 1.8-fold (0.26 log units) above it; low and high end bracket the measured number.
By their numbers in this assay, from the lowest: compounds 3, 2 and 1 (each within the scatter of the next, the first and the last beyond it).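

In this assay, this position on an oxygen next to a carbonyl group now shows a step beyond the scatter, though a modest one: sec-butyl in place of butyl gives a 2.1-fold lower number from compound 1 to compound 3 (0.32 log units; beyond the scatter) as the only such step among these chains. Sec-butyl in place of isobutyl gives a 1.7-fold lower number from compound 2 to compound 3 (0.22 log units; within the scatter) and stays within the scatter, so compound 2 and compound 3 cannot be ranked, and the rearranged chain separates only from butyl. Nothing shown here gives a measured reason for this difference between the chains. On these data alone, all three chains hold the same count of carbon atoms, so the effect of chain length is unknown. As far as these compounds go, how a longer chain such as hexyl, or a carboxylic acid in place of the ester, would read in this assay remains open.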